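The Hydroxyl-Bearing Side Chain: One Enantiomer Remains Unknown

The source may hold more compounds than are shown below. What is called first, only, known or untested is meant among the compounds shown, and "the series" means these compounds.

The measured compounds and their results in an assay on mitochondria (strain Sprague-Dawley) for inhibition of Amine oxidase [flavin-containing] B (Rattus norvegicus), read by spectrophotometry (a higher number here means a weaker inhibitor, a lower number a stronger inhibitor), are:
compound 1, `Cc1c(C)c2ccc(S(=O)(=O)Cc3ccccc3)cc2oc1=O`, 2750 nM
compound 2, `Cc1c(C)c2ccc(OC[C@@H](O)c3ccccc3)cc2oc1=O`, 28.2 nM
compound 3, `Cc1c(C)c2ccc(OCC(O)c3ccccc3)cc2oc1=O`, 70.8 nM

Compound 3 stands second highest of the three numbers in this assay; its nearest neighbour is compound 2, its furthest compound 1. The unmeasured compound 4 is `Cc1c(C)c2ccc(OC[C@H](O)c3ccccc3)cc2oc1=O`. It differs from compound 3 only in this: the two compounds have the same atoms and bonds; at least one stereo element is drawn with a configuration in one of them and without one in the other: 1 of 1 stereo elements differ; a stereocentre at a saturated chain carbon is drawn without a configuration in compound 3 and R in compound 4. For the measured compounds named here, one measured step bears on this change: a 2.5-fold higher number from compound 2 to compound 3 (0.40 log units; beyond the scatter), a step that is read as arising because of the fact that one of compounds 2 and 3 is drawn with a defined configuration and the other without, at the place where they differ. Compound 3, drawn without configuration, sits at a higher number than compound 2, drawn S, so the R form is expected to be the weaker member of the pair. Compound 4 is therefore expected to give a higher number than compound 3 in this assay, estimated as a 4.9-fold higher number from compound 3 to compound 4 (0.69 log units; beyond the scatter). The estimate for compound 4 is 350 nM, with a range from 100 nM to 1500 nM.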

Compound 4, half-maximal inhibitory concentration: 302 nM
Compound 4: the middle estimate sits 1.2-fold (0.06 log units) above what was measured; the measured number falls inside the stated range.
By their numbers in this assay, from the lowest: compound 2; then compound 3; then compound 4; then compound 1.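

With the R form now in hand, this assay gives both drawn configurations at the saturated chain carbon of the hydroxyl-bearing side chain, and the S form is the stronger inhibitor of the two. The step between them, an 11-fold higher number from compound 2 to compound 4 (1.03 log units; beyond the scatter), is larger than the one available before, a 2.5-fold higher number from compound 2 to compound 3 (0.40 log units; beyond the scatter), and it can be read as a matter of configuration alone: the fact that compounds 2 and 4 differ only in the configuration as drawn. The remaining step, a 4.3-fold higher number from compound 3 to compound 4 (0.63 log units; beyond the scatter), places the compound drawn without a configuration between the two defined forms, a difference read as follows: the fact that one of compounds 3 and 4 is drawn with a defined configuration and the other without, at the place where they differ.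

The compounds shown leave open whether an amine in place of the hydroxyl would keep this gap between the S and R forms. They also leave open whether a longer chain carrying the same hydroxyl would keep it.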